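Replacing the Ester Group on the Shared Core

A few compounds are considered here, and "the series" means these few. Any claim that something is new, unique, unknown or untested is made for them only; others in the source may bear on it.

Measured compounds:
compound 1 `O=C(CCCCC1CCSS1)NCc1cn(CCCOc2ccc3ccc(=O)oc3c2)nn1`: 40%
compound 2 `CCOC(=O)c1cc2ccc(OCCCn3cc(CNC(=O)CCCCC4CCSS4)nn3)cc2oc1=O`: 36.1%

In a functional assay on PC-12 cells (Rattus norvegicus) for cytotoxicity, read by MTT assay, with stated times of 3 h and 2 h, tested at 10 uM (a higher number here means a stronger effect of the compound at the concentration tested, a lower number a weaker effect), compound 1 gives 40% and compound 2 gives 36.1%. Going by the values given here, compound 2 holds the lower of the two numbers, but the one measured step, a number 3.9 percentage points lower from compound 1 to compound 2 (within the scatter), lies within the scatter, so the two compounds cannot be told apart on these data. That step adds an ethoxycarbonyl on an aromatic carbon of the shared core and leaves the read-out essentially where it was.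

Compound 3 `COc1ccc(-c2cc3ccc(OCCCn4cc(CNC(=O)CCCCC5CCSS5)nn4)cc3oc2=O)cc1` is the next compound. It differs from compound 2 at the same aromatic carbon: 4-methoxyphenyl in place of ethoxycarbonyl on an aromatic carbon. Among the compounds with values here, the only measured step bears on this change in that it concerns the same position and the same leaving group, and it was within the scatter. Nothing measured tells how a 4-methoxyphenyl at this position behaves, so the expectation leans on that one step alone. For compound 3 no step beyond the scatter is expected, the estimated step being a number 1.9 percentage points higher from compound 2 to compound 3 (within the scatter). Compound 3 is therefore expected to give 38%, with a range of 24% to 54%.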

Compound 3, a percentage reported as activity, at one concentration (the size of the read-out at that concentration, not a potency): 57.6%
Estimate against measurement, compound 3: 19.6 percentage points below; measured number outside the range, above it.
By their numbers in this assay, from the lowest: compounds 2 and 1 (each within the scatter of the next); then compound 3.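

The carbon on the shared core that seemed indifferent when ethoxycarbonyl replaced hydrogen does respond to what it carries: in this assay there is a number 21.5 percentage points higher from compound 2 to compound 3 (beyond the scatter), and against the unsubstituted core there is a number 17.6 percentage points higher from compound 1 to compound 3 (beyond the scatter). So this position can move the read-out beyond the scatter, and of the groups shown only 4-methoxyphenyl does so, while hydrogen and ethoxycarbonyl cannot be told apart. The change brings in a six-membered aromatic ring of carbon only, which ethoxycarbonyl lacks, but no measurement here explains why the read-out rises.

With a single aryl group at this carbon, the compounds shown leave open whether the ring alone carries the step or the methoxy on it also matters, a question that a plain phenyl would address, and whether a carboxylic acid or an amine in the same place would behave like ethoxycarbonyl or like 4-methoxyphenyl. They also leave open whether the step would keep its size at other concentrations, since each compound is read at a single one.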